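The source may report more compounds than this note shows. Statements on the series, on what has been measured and on what is new or still open speak of the compounds shown alone.

Working notes on the series. Compound 1 `O=C1CSC(c2ccccc2[N+](=O)[O-])N1CCN1CCCCC1` and compound 2 `O=C1CSC(c2ccc(F)cc2)N1CCN1CCCCC1` share one core and differ only in the aryl group on the saturated ring carbon. In an ADME assay on Vero cells (Chlorocebus sabaeus) for cytotoxicity, read by neutral red uptake, tested at 25 ug/mL (on this read-out lower numbers stand for a stronger effect and higher numbers for a weaker effect at the one concentration tested), compound 1 gives 100% and compound 2 gives 100%. Compound 2 thus stands level with compound 1 at the digits shown; the two readings lie within the scatter of each other, and no order can be drawn between them.

Compound 3 `O=C1CSC(c2ccccc2Cl)N1CCN1CCCCC1` is the next member. Relative to compound 2 the change is 2-chlorophenyl in place of 4-fluorophenyl on a saturated ring carbon.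

Among the measured compounds shown here, no step between two measured compounds is available here, so the expected size of the step in this assay rests only on the two readings at hand. Since both sit at the top of the scale, the expectation is no step beyond the scatter: the expected step is no change at the digits printed from compound 2 to compound 3 (within the scatter). Compound 3 is therefore estimated at 100%, with a range from 88% to 100%.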

Compound 3, a percentage reported as activity, at one concentration (the size of the read-out at that concentration, not a potency): 100%
The estimate for compound 3 equals the measured number at the digits printed; the range from low to high includes it.
By their numbers in this assay, from the lowest: compounds 1, 2 and 3 (each within the scatter of the next).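

In this assay, 2-chlorophenyl in place of 4-fluorophenyl on a saturated ring carbon gives no change at the digits printed from compound 2 to compound 3 (within the scatter), and chloro in place of nitro on an aromatic carbon gives no change at the digits printed from compound 1 to compound 3 (within the scatter). This adds a chlorine-bearing aryl group to the nitro- and fluorine-bearing ones, so all three aryl groups at this position now read alike, and the chloro-for-nitro swap gives the series its first readable single-group step on the aromatic ring.

On these data alone, whether the same reading holds for an aryl ring carrying an amine or a carboxylic acid, or for a longer alkyl chain in place of the aryl group, remains open. The one tested concentration also leaves open how these compounds compare at other concentrations. No measurement at hand offers an explanation for these matching readings.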